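Bromo in place of ethyl: from compound 1 to compound 3

A few compounds are considered here, and "the series" means these few. Any claim that something is new, unique, unknown or untested is made for them only; others in the source may bear on it.

Measured in an assay on isolated protein for inhibition of aldehyde dehydrogenase 1A1 (Homo sapiens), read by spectrophotometry, tested at 10 uM; a higher number here means more inhibition at the concentration tested (going by the name of the read-out), a lower number less inhibition:
- compound 1 `CCc1ccc(C(=O)N2CCN(Cc3nc4ccccc4n3Cc3cccc(C)c3)CC2)cc1`: 67%
- compound 2 `Cc1cccc(Cn2c(OC3CCN(C(=O)C4CC4)CC3)nc3ccccc32)c1`: 80.6%

Compound 1 gives the lower of the two numbers in this assay; the gap to compound 2 lies beyond the usual scatter. Among the measured compounds shown here, compound 2 shares the core with compound 1 but differs in several places at once, so the pair shows only its two values and supports no single step.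

Compound 3 `Cc1cccc(Cn2c(CN3CCN(C(=O)c4ccc(Br)cc4)CC3)nc3ccccc32)c1` is not yet measured. It differs from compound 1 in one place: bromo in place of ethyl on an aromatic carbon. For the measured compounds named here, no measured pair isolates this change, so nothing says how large the step will be. Given that bromo and ethyl are each a small group on the same aromatic carbon, the expected step is none beyond the scatter, in either direction.

For compound 3 the estimate in this assay is 65%, within 45% to 85%, an expected step of a number 2 percentage points lower from compound 1 to compound 3 (within the scatter).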

Compound 3, a percentage reported as inhibition, at one concentration (the size of the read-out at that concentration, not a potency): 25.8%
The estimate for compound 3 lay 39.2 percentage points above the measured number, and the stated range ends above it.
By their numbers in this assay, from the lowest: compound 3; then compound 1; then compound 2.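

In this assay, the change from 4-ethylphenyl to 4-bromophenyl gives a number 41.2 percentage points lower from compound 1 to compound 3 (beyond the scatter), so this aromatic carbon of the (4-ethylphenyl)carbonyl group is not indifferent to the group it carries. Ethyl and bromo differ here by one heavy atom, and neither has a hydrogen-bond donor or acceptor, yet the step lies beyond the scatter. Nothing at hand accounts for its size.

The compounds shown do not separate a loss tied to bromo from a gain tied to ethyl, as only these two groups can be compared at this carbon. A longer chain such as propyl, a methoxy group or an amine at the same carbon would show whether the number tracks ethyl alone or varies more widely with the group.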